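The source may report more compounds than this note shows. Statements on the series, on what has been measured and on what is new or still open speak of the compounds shown alone.

Measured in a functional assay on A-375 cells (Homo sapiens) for inhibition, read by CCK-8 assay, with a stated time of 72 h, tested at 8 uM (a higher number here means more inhibition of growth at the concentration tested, a lower number less inhibition of growth), so far:
- compound 1 `CCc1ccc(SCc2ccc(/C=C/C(=O)Nc3ccccc3N)cc2)cc1` gives 58.4%
- compound 2 `CCc1ccc(SCc2ccc(C(=O)Nc3ccccc3N)cc2)cc1` gives 71.1%

Of the two numbers in this assay the higher belongs to compound 2 at 71.1%. For the measured compounds named here, compound 1 gives 58.4% as the only other value. The gap between these two numbers lies beyond the scatter.

Compound 3 `Nc1ccccc1NC(=O)c1ccc(CSc2ccc(Br)cc2)cc1` is not yet measured. The change from compound 2 is bromo in place of ethyl on an aromatic carbon with bromo in place of ethyl on an aromatic carbon, para to a large group. Going by the values given here, no measured pair tests this swap, so the expectation rests on compound 2 at 71.1% alone. No step beyond the scatter is expected, with a slight decrease as the best guess: the estimated a number 3.1 percentage points lower from compound 2 to compound 3 (within the scatter) stays within it. For compound 3 the expected value is 68% with an estimated range of 52% to 82% in this read-out.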

Compound 3, percent growth inhibition at one concentration: 6.17%
For compound 3 the middle estimate is 61.8 percentage points above the measured one; the measured number lies below the stated range.
By their numbers in this assay, from the lowest: compound 3; then compound 1; then compound 2.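

Bromo in place of ethyl on the aromatic carbon para to a large group gives a number 64.9 percentage points lower from compound 2 to compound 3 (beyond the scatter) in this assay, so growth inhibition at the concentration tested depends strongly on the group at this position. Neither group has a ring, a hydrogen-bond donor or acceptor, or a net charge, so a step of this size here needs no change in any of these. Nothing at hand gives a cause for this step.

From the compounds shown here alone, with a single pair at this position, it remains open whether ethyl is especially favourable or bromo especially unfavourable; methyl, chloro or a longer chain such as propyl at the same place would help separate the two. Going by these compounds, it also remains open whether the same swap on the core of compound 1 gives a step of similar size.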